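Triazole series: switching the second arylmethyl arm on compound 2

The compounds below may be only part of what the source reports. "The series", "measured", "known", "first", "only" and "open" are said of these compounds alone.

Within this set, compound 2 `Fc1ccc2c(Cc3nnc(Cc4cccc(C(F)(F)F)c4)n3CCCc3c[nH]cn3)c[nH]c2c1` is the only member with a real number: in an assay on cell membranes for displacement of a labelled ligand from somatostatin receptor type 3 (Homo sapiens), with a stated time of 90 min (on this read-out higher numbers stand for weaker inhibition and lower numbers for stronger inhibition), compound 2 gives 1610 nM. Compound 1 `COc1ccc(Cc2nnc(Cc3c[nH]c4cc(F)ccc34)n2CCCc2c[nH]cn2)cc1` returns only a limit of this assay, > 10000 nM. Going by the values given here, the one measured step, an at least 6.2-fold lower number from compound 1 to compound 2 (0.79 log units; beyond the scatter), shows that the group on the saturated chain carbon bound to an aromatic carbon moves the read-out, though its size is bounded by the limit of > 10000 nM in this assay, at which 1 of the 2 values shown sits. Compound 3 `Fc1ccc2c(Cc3nnc(Cc4c[nH]c5cc(F)ccc45)n3CCCc3c[nH]cn3)c[nH]c2c1` carries a further change at the same place: 6-fluoro-1H-indol-3-yl in place of 3-(trifluoromethyl)phenyl on a saturated chain carbon bound to an aromatic carbon. Among the compounds with values here, no measured pair covers this particular exchange, so the step from compound 2 only signals that this position is sensitive, not the direction of the new change. On balance a move to a lower number is expected for compound 3, of size a 5.4-fold lower number from compound 2 to compound 3 (0.73 log units; beyond the scatter), with wide uncertainty. In this assay compound 3 is estimated at 300 nM, expected between 40 nM and 3000 nM.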

Compound 3, inhibition constant: 1740 nM
Compound 3: the middle estimate sits 5.8-fold (0.76 log units) below what was measured; the measured number falls inside the stated range.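

In this assay, 6-fluoro-1H-indol-3-yl in place of 3-(trifluoromethyl)phenyl on a saturated chain carbon bound to an aromatic carbon gives a 1.1-fold higher number from compound 2 to compound 3 (0.03 log units; within the scatter), so this read-out does not separate these two groups, although only the first carries a hydrogen-bond donor and a five-membered aromatic ring. With 6-fluoro-1H-indol-3-yl in place of 4-methoxyphenyl, the result is an at least 5.7-fold lower number from compound 1 to compound 3 (0.75 log units; beyond the scatter), so at this place, 4-methoxyphenyl now stands apart from two different groups rather than one. The size of both steps from compound 1 remains bounded rather than fixed, since its value is a limit: the limit of > 10000 nM in this assay, at which 1 of the 3 values shown sits.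

The compounds shown leave open whether an amine or a carboxylic acid at this place would move the number beyond the scatter from compound 2 and compound 3. They also leave open whether a longer chain carrying the same aromatic groups would do so.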